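Ethyl for dimethylamino: what compound 4 might show

The source may report more compounds than this note shows. Statements on the series, on what has been measured and on what is new or still open speak of the compounds shown alone.

Compound 1 `Cc1cc(NC(=O)Nc2ccc(C(=O)O)cc2)c2ccccc2n1`: in an ADME assay on Raji cells (Homo sapiens) for cytotoxicity, with a stated time of 72 h (a lower number here means that less compound is needed, a higher number that more compound is needed for the effect), compound 1 gives > 25000 nM, a limit of the assay.
Compound 2 `Cc1ccc(NC(=O)Nc2cc(C)nc3ccccc23)cc1`: in this assay compound 2 gives > 25000 nM, again a limit.
Compound 3 `Cc1cc(NC(=O)Nc2ccc(N(C)C)cc2)c2ccccc2n1`: in this assay compound 3 gives > 25000 nM, once more a limit.

Compound 3 therefore stands where every measured compound stands, at the limit of > 25000 nM in this assay, at which 3 of the 3 values shown sit, and nothing in these numbers separates it from compound 1 or compound 2. The step from compound 3 to compound 4 `CCc1ccc(NC(=O)Nc2cc(C)nc3ccccc23)cc1` is ethyl in place of dimethylamino on an aromatic carbon. The measured step closest to it is a step that the two limits leave unreadable from compound 2 to compound 3, which runs the other way between a small alkyl group and dimethylamino and which the two limits leave unreadable; a step that the two limits leave unreadable from compound 1 to compound 3 and a step that the two limits leave unreadable from compound 1 to compound 2 are unreadable in the same way. With every anchor at the limit, no direction or size can be read for the present change, and the expectation is that compound 4 remains at the limit as well. The step that the limit leaves unreadable from compound 3 to compound 4 is thus expected to be none that the data could show. Compound 4 is estimated at 40000 nM, between 15000 nM and 120000 nM, most likely reported only as a limit.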

Compound 4, half-maximal effective concentration: > 25000 nM
Compound 4: only a limit was reported; the forecaster's own chance of this, stated with the estimate: 85%; the middle value lies beyond the limit too.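

In this assay compound 4 gives > 25000 nM as a limit of the assay. No step can be read between compound 4 and compound 1, compound 2 or compound 3, since all four share one limit: the limit of > 25000 nM in this assay, at which 4 of the 4 values shown sit. The compounds shown leave open how far any of them lies beyond that limit, and which structural change, if any, would bring a value within the range of the assay.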